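The compounds below may be only part of what the source reports. "The series", "measured", "known", "first", "only" and "open" are said of these compounds alone.

Measured in an ADME assay on microsomes from liver (Homo sapiens) for metabolic stability, read by LC-MS, with a stated time of 10 min; a lower number here means that less of the compound is left, a higher number that more of the compound is left:
- Compound 1 `CN(C[C@H]1Cc2c(cccc2N2CCNC(C)(C)C2)CN1)[C@H]1CCCc2cccnc21`: 100%
- Compound 2 `CN(C[C@H]1Cc2c(cccc2N2CCN(Cc3ccccn3)CC2)CN1)[C@H]1CCCc2cccnc21`: 4.2%
- Compound 3 `CCN(C[C@H]1Cc2c(cccc2N2CCNCC2)CN1)[C@H]1CCCc2cccnc21`: 79.1%

Compound 1 stands highest of the three at 100%. Compound 3 comes nearest at 79.1%, and compound 2 lies furthest off at 4.2%, both lower beyond the scatter.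

Compound 4 `CN(C[C@H]1Cc2c(cccc2N2C[C@H]3C[C@@H]2CN3)CN1)[C@H]1CCCc2cccnc21` has not yet been measured. It departs from compound 1 at one place, on an aromatic carbon, where the 3,3-dimethylpiperazin-1-yl group is replaced: a group of 7 heavy atoms (5 carbon, 2 nitrogen; 2 five-membered non-aromatic rings with 1 hetero atom each) in place of a group of 8 heavy atoms (6 carbon, 2 nitrogen; one six-membered non-aromatic ring with 2 hetero atoms), on an aromatic carbon. The entering group also has 2 defined stereocentres.

Within the data shown here, no measured pair isolates a change at one place, so the expectation rests on the overall spread. Compound 1 at 100% and compound 3 at 79.1% both remain high, while compound 2 at 4.2% shows how far the value can fall. A modest fall in this assay is therefore expected, and the estimated step is a number 15 percentage points lower from compound 1 to compound 4 (beyond the scatter). For compound 4 the expected value is 85%, with an estimated range from 60% to 100%.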

Compound 4, percent of the compound remaining: 100%
Estimate against measurement, compound 4: 15 percentage points below; measured number inside the range.
By their numbers in this assay, from the lowest: compound 2; then compound 3; then compounds 1 and 4 (each within the scatter of the next).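

In this assay, replacing the 3,3-dimethylpiperazin-1-yl group on the aromatic carbon gives no change at the digits printed from compound 1 to compound 4 (within the scatter), the only step among these compounds that isolates a change at one place. It shows that, on the core of compound 1, this position accepts a group with two five-membered non-aromatic rings and 2 defined stereocentres in place of the six-membered ring, with no loss in the percentage remaining. No measurement shown here accounts for this outcome.

The compounds shown leave open whether a different group at this position, such as morpholin-4-yl or a plain dimethylamino group, would also leave the value unchanged. Among these compounds, with compound 1 at 100% and compound 4 at 100%, they also leave open whether the same exchange would make no difference on a compound starting from a lower value.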